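A cyano group on the pyridin-2-yl ring of compound 1

The source may hold more compounds than are shown below. What is called first, only, known or untested is meant among the compounds shown, and "the series" means these compounds.

Compound 1 `O/N=C(\CCN1CCN(c2ccccn2)CC1)c1ccccc1` is the parent of this small set. In a functional assay on HEK293 cells with D(4) dopamine receptor (Homo sapiens) as the target, read by FLIPR (on this read-out higher numbers stand for an effect only at larger amounts of compound and lower numbers for an effect already at smaller amounts), compound 1 gives 4.4 nM, the second highest of the three numbers recorded so far. Compound 2 `Cc1ccccc1/C(CCN1CCN(c2ccccn2)CC1)=N/O` carries a methyl in place of hydrogen on an aromatic carbon, and in this assay compound 2 gives 4.2 nM; the step of a 1.0-fold lower number from compound 1 to compound 2 (0.02 log units; within the scatter) stays within the scatter. Compound 3 `Cc1ccc(O)c(/C(CCN2CCN(c3ccccn3)CC2)=N/O)c1` bears 2-hydroxy-5-methylphenyl in place of phenyl on the carbon with a double bond to nitrogen, and in this assay compound 3 gives 19.2 nM; the step of a 4.4-fold higher number from compound 1 to compound 3 (0.64 log units; beyond the scatter) is modest, as is the related step of a 4.6-fold higher number from compound 2 to compound 3 (0.66 log units; beyond the scatter).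

Compound 4 `N#Cc1cccnc1N1CCN(CC/C(=N\O)c2ccccc2)CC1` differs from compound 1 by cyano in place of hydrogen on an aromatic carbon. Among the compounds with values here, none of the measured steps touches this part of the molecule: all three concern the aryl group on the carbon with a double bond to nitrogen, where a small addition cost nothing and a larger change cost a modest amount. Within the data shown here, with no direct precedent, the step of a 1.1-fold higher number from compound 1 to compound 4 (0.06 log units; within the scatter) expected for compound 4 in this assay is small, not beyond the scatter. Compound 4 is therefore estimated at 5 nM in this assay, with a range from 1.5 nM to 20 nM.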

Compound 4, half-maximal effective concentration: 18 nM
Estimate against measurement, compound 4: 3.6-fold (0.56 log units) below, within the range that was stated.
By their numbers in this assay, from the lowest: compounds 2 and 1 (each within the scatter of the next); then compounds 4 and 3 (each within the scatter of the next).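

The pyridin-2-yl ring proves to be a place where a small change registers in this assay: the change to 3-cyanopyridin-2-yl gives a 4.1-fold higher number from compound 1 to compound 4 (0.61 log units; beyond the scatter), a modest step towards needing more compound for the effect. This contrasts with the addition of methyl on the phenyl ring, which gives a 1.0-fold lower number from compound 1 to compound 2 (0.02 log units; within the scatter), and it shows that a group of only 2 heavy atoms, placed ortho to a large group and two atoms from the ring nitrogen, can shift the number about as much as the larger aryl change, a 4.4-fold higher number from compound 1 to compound 3 (0.64 log units; beyond the scatter), which is also rated modest. No measurement at hand accounts for this shift in terms of any property of the cyano group.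

As far as these compounds go, it remains open whether this step belongs to cyano itself or would also appear with a methyl group, a chlorine atom or a methoxy group at the same carbon, and whether cyano on another carbon of the pyridine ring would behave alike. Also open, from the compounds shown here alone, is how 3-cyanopyridin-2-yl would combine with 2-methylphenyl or 2-hydroxy-5-methylphenyl in place of phenyl.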